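Pyrazole to Triazole Swap on the Benzylic Carbon

A few compounds are considered here, and "the series" means these few. Any claim that something is new, unique, unknown or untested is made for them only; others in the source may bear on it.

Measured compounds:
Compound 1 `Cc1cc(C(=O)O)nn1Cc1cc(Br)ccc1OCc1ccccc1` gives 15.1 nM in a functional assay on CHO-K1 cells for antagonist activity at prostaglandin E2 receptor EP1 subtype (Homo sapiens), read by FLIPR; on this read-out lower numbers stand for stronger inhibition and higher numbers for weaker inhibition.
Compound 2 `O=C(O)c1ccn(Cc2cc(Br)ccc2OCc2ccccc2)n1` gives 55 nM in this assay.
Compound 3 `O=C(O)c1nn(Cc2cc(Br)ccc2OCc2ccccc2)cc1Br` gives only a limit in this assay, < 2000 nM.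

Compound 2 stands highest of the two numbers read out; compound 1 lies nearest, with a 3.6-fold higher number from compound 1 to compound 2 (0.56 log units; beyond the scatter). A second step, a step that the limit leaves unreadable from compound 2 to compound 3, cannot be sized since it sits at the limit of < 2000 nM in this assay, at which 1 of the 3 values shown sits. Compound 4 `O=C(O)c1cn(Cc2cc(Br)ccc2OCc2ccccc2)nn1` carries 4-carboxy-1H-1,2,3-triazol-1-yl in place of 3-carboxy-1H-pyrazol-1-yl on a saturated chain carbon bound to an aromatic carbon. Neither measured step touches the ring itself; both alter substituents on it, one modestly, one beyond reading. A modest rise in this assay is therefore expected, a 1.8-fold higher number from compound 2 to compound 4 (0.26 log units; within the scatter). Compound 4 is estimated at 100 nM, with a range from 25 nM to 400 nM.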

Compound 4, inhibition constant: < 2000 nM
Compound 4: a limit, no number; the forecaster's own chance of this, stated with the estimate: 10%; the middle value lies beyond the limit too.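

Compound 4 gives only a limit in this assay, not a number, so the step from compound 2 to this compound cannot be read: the limit of < 2000 nM in this assay, at which 2 of the 4 values shown sit.

Going by these compounds, how 4-carboxy-1H-1,2,3-triazol-1-yl truly compares with 3-carboxy-1H-pyrazol-1-yl in this position stays open.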